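Replacing the 1,3-oxazol-2-yl group of compound 3

The source may hold more compounds than are shown below. What is called first, only, known or untested is meant among the compounds shown, and "the series" means these compounds.

Measured so far in an in vivo ADME assay on the whole organism (plasma) for pharmacokinetics, with Rattus norvegicus as the target, at a dose of 50 mg/kg by the oral route; on this read-out higher numbers stand for higher exposure at the dose given and lower numbers for lower exposure:
- compound 1 `Cc1cc(C)c(OC2CC2)c(C)c1NC(=O)c1sccc1S(=O)(=O)Nc1onc(C)c1Cl`: 12300 nM
- compound 2 `Cc1cc(C)c(NS(C)(=O)=O)c(C)c1NC(=O)c1sccc1S(=O)(=O)Nc1onc(C)c1Cl`: 5250 nM
- compound 3 `Cc1cc(C)c(NC(=O)c2sccc2S(=O)(=O)Nc2onc(C)c2Cl)c(-c2ncco2)c1`: 134000 nM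

Compound 3 stands highest of the three, and its gaps to the other two lie well beyond the usual scatter. The next molecule, compound 4 `Cc1cc(C)c(NC(=O)c2sccc2S(=O)(=O)Nc2onc(C)c2Cl)c(C(=O)CS(C)(=O)=O)c1`, changes one place of compound 3: ((methylsulfonyl)methyl)carbonyl in place of 1,3-oxazol-2-yl on an aromatic carbon. The new group sits on an aromatic carbon, where the 1,3-oxazol-2-yl group stood.

Going by the values given here, only one measured step is available as a guide: a 2.3-fold lower number from compound 1 to compound 2 (0.37 log units; beyond the scatter). Among the compounds with values here, that modest step swapped other groups, so it bears only loosely on this change, and no measurement yet shows what removing the 1,3-oxazol-2-yl group does. Still, the two compounds lacking that group are far lower, with compound 1 at 12300 nM and compound 2 at 5250 nM. A drop larger than the modest step, and beyond the scatter, is therefore expected: a 6.1-fold lower number from compound 3 to compound 4 (0.78 log units; beyond the scatter). The estimate for compound 4 is 22000 nM, with an expected range of 5000 nM to 90000 nM.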

Compound 4, maximal plasma concentration: 68300 nM
Compound 4: the middle estimate sits 3.1-fold (0.49 log units) below what was measured; low and high end bracket the measured number.
By their numbers in this assay, from the lowest: compound 2; then compound 1; then compounds 4 and 3 (each within the scatter of the next).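

In this assay, replacing the ring with an open chain gives a 2.0-fold lower number from compound 3 to compound 4 (0.29 log units; within the scatter), so this read-out does not separate the two compounds. On this aromatic carbon, ortho to a large group, the five-membered aromatic ring of 1,3-oxazol-2-yl can therefore give way to ((methylsulfonyl)methyl)carbonyl, which has no ring, with no change in exposure beyond the usual scatter; for this pair, a ring at this place is not required. Nothing available offers an explanation for this result.

From the compounds shown here alone, whether a simple amine or a carboxylic acid at this place would give similar exposure remains open. So does the question of which part of the new chain, the carbonyl or the methylsulfonyl end, matters for exposure, since a single pair cannot separate the two.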